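A few compounds are considered here, and "the series" means these few. Any claim that something is new, unique, unknown or untested is made for them only; others in the source may bear on it.

Compound 1 `Cc1nc(-c2ccc(C(F)(F)F)cc2)sc1CNc1ccc(CCC(=O)O)cc1`: 67.6 nM
Compound 2 `Cc1nc(-c2ccc(C(F)(F)F)cc2)sc1CNc1ccc(CC(=O)O)cc1`: < 10000 nM, a limit of the assay
Compound 3 `Cc1nc(-c2ccc(C(F)(F)F)cc2)sc1CNc1ccc(/C=C/C(=O)O)cc1`: 36.3 nM

In a functional assay on CHO cells for agonist activity at Free fatty acid receptor 1 (Homo sapiens) (on this read-out higher numbers stand for an effect only at larger amounts of compound and lower numbers for an effect already at smaller amounts), compound 3 gives 36.3 nM, the lowest of the two read numbers, and compound 1 is nearest with 67.6 nM; the step of a 1.9-fold lower number from compound 1 to compound 3 (0.27 log units; within the scatter). Compound 2 gives < 10000 nM, which is a limit and not a number. For that reason the step that the limit leaves unreadable from compound 2 to compound 3.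

Compound 4, `Cc1nc(-c2ccc(C(F)(F)F)cc2)sc1CNc1ccc(OCC(=O)O)cc1`, differs from compound 3 in one place: carboxymethoxy in place of 2-carboxyethenyl on an aromatic carbon. For the measured compounds named here, both groups carry the same count of heavy atoms, so the change resembles the one readable step, a 1.9-fold lower number from compound 1 to compound 3 (0.27 log units; within the scatter), which stayed within the scatter, rather than the shortening in compound 2 that reached a limit. The expected step is therefore a 2.5-fold higher number from compound 3 to compound 4 (0.39 log units; beyond the scatter). Compound 4 is estimated at 90 nM, within 25 nM to 400 nM.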

Compound 4, half-maximal effective concentration: 288 nM
Estimate against measurement, compound 4: 3.2-fold (0.51 log units) below; the measured number falls inside the stated range.
By their numbers in this assay, from the lowest: compounds 3 and 1 (each within the scatter of the next); then compound 4.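

In this assay, carboxymethoxy in place of 2-carboxyethenyl, with the same count of heavy atoms, gives a 7.9-fold higher number from compound 3 to compound 4 (0.90 log units; beyond the scatter), and carboxymethoxy in place of 2-carboxyethyl gives a 4.3-fold higher number from compound 1 to compound 4 (0.63 log units; beyond the scatter). So on this aromatic carbon, para to a large group, an equal heavy-atom count does not keep the number, although compound 1 and compound 3 lie within the scatter of each other. Compound 2 carries a limit, so its steps cannot be read: the limit of < 10000 nM in this assay, at which 1 of the 4 values shown sits.

The compounds shown do not explain why carboxymethoxy gives the higher number. Also open, as far as these compounds go, is how a longer chain ending in the acid, or an amide in place of the acid, would read.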